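The source may hold more compounds than are shown below. What is called first, only, known or untested is meant among the compounds shown, and "the series" means these compounds.

Compound 1 `O=C(Nc1ccc(-c2cscn2)cc1)C1CCCN(Cc2ccc(F)c(F)c2)C1`: 880 nM
Compound 2 `O=C(Nc1ccc(-c2cscn2)cc1)C1CCCN(Cc2ccccc2F)C1`: 4000 nM
Compound 3 `O=C(Nc1ccc(-c2cscn2)cc1)C1CCCN(Cc2cccc(F)c2)C1`: 2450 nM

All three were tested in a functional assay on A-375 cells (Homo sapiens) for antiproliferative activity; on this read-out higher numbers stand for weaker inhibition and lower numbers for stronger inhibition. Compound 3 groups with compound 2 rather than with compound 1. The gap within that group is a 1.6-fold lower number from compound 2 to compound 3 (0.21 log units; within the scatter), while the other gap is a 2.8-fold higher number from compound 1 to compound 3 (0.44 log units; beyond the scatter), with hydrogen in place of fluoro on an aromatic carbon.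

Compound 4 `O=C(Nc1ccc(-c2cscn2)cc1)C1CCCN(Cc2ccc(F)cc2)C1` differs from compound 3 by a single change: 4-fluorophenyl in place of 3-fluorophenyl on a saturated chain carbon bound to an amine nitrogen in a ring.

Moving the single fluoro has so far given only a 1.6-fold lower number from compound 2 to compound 3 (0.21 log units; within the scatter), so another such move is expected to stay small in this assay. The larger steps, a 4.5-fold higher number from compound 1 to compound 2 (0.66 log units; beyond the scatter) and a 2.8-fold higher number from compound 1 to compound 3 (0.44 log units; beyond the scatter), both start from compound 1, which carries one more fluoro. The 4-fluorophenyl of compound 4 keeps the fluoro removed in the second of these, so a slightly lower number is expected, within the scatter. The expected step is a 1.4-fold lower number from compound 3 to compound 4 (0.13 log units; within the scatter).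

For compound 4 the estimated value is 1800 nM, with an expected range from 800 nM to 4000 nM.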

Compound 4, half-maximal inhibitory concentration: 2250 nM
Beside the measured number, compound 4's estimate is 1.3-fold (0.10 log units) below it; low and high end bracket the measured number.
By their numbers in this assay, from the lowest: compound 1; then compounds 4, 3 and 2 (each within the scatter of the next).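

In this assay the 4-fluorophenyl on a saturated chain carbon bound to an amine nitrogen in a ring completes the set of single-fluoro compounds, and the place of the fluoro makes no difference that can be read: the data give a 1.1-fold lower number from compound 3 to compound 4 (0.04 log units; within the scatter) and a 1.8-fold lower number from compound 2 to compound 4 (0.25 log units; within the scatter) and both lie within the scatter. Against this set, compound 1 now stands apart from all three single-fluoro compounds, with a 2.6-fold higher number from compound 1 to compound 4 (0.41 log units; beyond the scatter) adding to the two earlier steps of this kind, so only the 3,4-difluorophenyl of compound 1 separates from the rest. Nothing measured here explains this separation.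

Going by these compounds, it remains open whether a 2,4-difluorophenyl would match compound 1 or fall with the single-fluoro compounds. On these data alone, it also remains open how chloro or methoxy in place of the fluoro would read in this assay on this same carbon.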